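The compounds below may be only part of what the source reports. "The series", "measured", "known", "first", "only" and "open" are said of these compounds alone.

In a functional assay on K562 cells (Homo sapiens) for antiproliferative activity, read by MTT assay, with a stated time of 48 h (a higher number here means a weaker inhibitor of growth, a lower number a stronger inhibitor of growth), compound 1 `COc1ccc(N(C)c2nc(Cl)nc3[nH]cnc23)cc1` gives only a limit of > 100000 nM and no number. Compound 3 `COc1ccc(Cn2cnc3c(Cl)ncnc32)cc1` fares no differently: its result is the limit > 50000 nM and not a measured value. Every result so far is a limit of this kind, so compound 3 cannot be ranked against the other compounds, and nothing yet shows at what concentration it would inhibit growth.

Compound 4 `COc1ccc(Cn2cnc3c(Cl)ncnc32)cc1OC` differs from compound 3 in one place: methoxy in place of hydrogen on an aromatic carbon. The change is methoxy in place of hydrogen on an aromatic carbon, and the new group stands ortho to the existing methoxy group. Compound 2 `COc1ccc(N(C)c2ncnc3c2ncn3Cc2ccc(OC)c(OC)c2)cc1` already carries that pair of methoxy groups on a different core. Among the compounds with values here, compound 2 also ends at a limit, > 100000 nM and so offers no sign that the pair brings measurable growth inhibition.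

On that basis, the expected change in this assay is a number no higher from compound 3 to compound 4 (the limit leaves the size open) and it is estimated to stay within the usual scatter, with no direction foreseen. For compound 4 the estimated value is 50000 nM with an expected range from 15000 nM to 100000 nM in this reading. A further limit instead of a number would be no surprise.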

Compound 4, concentration for 50% growth inhibition: > 50000 nM
Compound 4 gave a limit, no number; the forecaster's own chance of this, stated with the estimate: 65%; the middle value lies on the limit itself.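

In this assay compound 4 gives > 50000 nM, a limit and not a number. Compound 2 and compound 3 also end at limits, so the steps from each of them to compound 4 cannot be read. The compounds shown leave open whether any of them inhibits growth at a concentration that can be given as a number.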